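This account rests on a few compounds, and the source may have more. Where it says the series, first, only, none or still open, it means among the compounds named here.

In a functional assay on SH-SY5Y cells (Homo sapiens) for inhibition, read by sulforhodamine B assay (on this read-out lower numbers stand for stronger inhibition and higher numbers for weaker inhibition), three compounds sharing one core have been read so far. Compound 1 (`COC(=O)CC/C(C)=C/Cc1c(OC)c(C)c2c(c1OCC#CCN1CCN(c3ccc(O)cc3)CC1)C(=O)OC2`) gives 46100 nM, compound 2 (`COC(=O)CC/C(C)=C/Cc1c(OC)c(C)c2c(c1OCC#CCN1CCN(c3ccccc3OC)CC1)C(=O)OC2`) gives 43600 nM, and compound 3 (`COC(=O)CC/C(C)=C/Cc1c(OC)c(C)c2c(c1OCC#CCN1CCCc3ccccc31)C(=O)OC2`) gives 9570 nM. Compound 3 holds the lowest of the three numbers, and its gaps to the other two lie beyond the scatter.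

The next compound is compound 4 (`CCCCNc1ccc(CC#CCOc2c(C/C=C(\C)CCC(=O)OC)c(OC)c(C)c3c2C(=O)OC3)cc1`), and its difference from compound 3 is 4-(butylamino)phenyl in place of 1,2,3,4-tetrahydroquinolin-1-yl on a saturated chain carbon bound to a triple-bonded carbon. In short, 4-(butylamino)phenyl stands in place of 1,2,3,4-tetrahydroquinolin-1-yl on a saturated chain carbon bound to a triple-bonded carbon.

Among the compounds with values here, only one measured step offers any guide: a 1.1-fold lower number from compound 1 to compound 2 (0.02 log units; within the scatter). That step exchanges 4-hydroxyphenyl for 2-methoxyphenyl on an amine nitrogen in a ring, so it does not test the present change. Within the data shown here, no measured pair does. The remaining guide is the spread of the readings, with compound 3 at the low end and compound 2 at 43600 nM at the high end. Some loss of the low number of compound 3 is expected, though not all the way to that high end. The expected step is a 2.1-fold higher number from compound 3 to compound 4 (0.32 log units; beyond the scatter), a moderate move toward a higher number. For compound 4 the estimated value is 20000 nM, with an expected range of 7000 nM to 50000 nM.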

Compound 4, half-maximal inhibitory concentration: 5960 nM
The estimate for compound 4 lay 3.4-fold (0.53 log units) above the measured number, and the stated range ends above it.
By their numbers in this assay, from the lowest: compounds 4 and 3 (each within the scatter of the next); then compounds 2 and 1 (each within the scatter of the next).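

On a saturated chain carbon bound to a triple-bonded carbon, putting 4-(butylamino)phenyl in place of 1,2,3,4-tetrahydroquinolin-1-yl in this assay gives a 1.6-fold lower number from compound 3 to compound 4 (0.21 log units; within the scatter), so compound 3 and compound 4 cannot be told apart on this read-out. The exchange removes the six-membered non-aromatic ring and adds a hydrogen-bond donor, and neither difference comes with a reading beyond the scatter, so for this pair the low reading does not depend on keeping the 1,2,3,4-tetrahydroquinolin-1-yl group. No measurement at hand gives a cause for this result.

The compounds shown leave open which part of the 4-(butylamino)phenyl group counts, since the butyl chain and its amine hydrogen change together with the ring in this single step. A shorter methylamino group, a longer hexylamino chain, a dimethylamino group or a carboxylic acid in place of the butylamino group would separate these parts and show whether the reading in this assay holds.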